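The source may report more compounds than this note shows. Statements on the series, on what has been measured and on what is new or still open speak of the compounds shown alone.

Of the compounds shown here, three built on one shared core have been tested in a functional assay on SR cells (Homo sapiens) for inhibition, read by sulforhodamine B assay, with a stated time of 48 h; on this read-out lower numbers stand for stronger inhibition of growth and higher numbers for weaker inhibition of growth. Compound 1 `Nc1cc(N)c2nc(-c3ccccc3)c(Oc3ccc(Cl)c(Cl)c3)nc2c1` gives 33900 nM in this assay. Compound 2 `CCOC(=O)[C@H](CCC(=O)O)NC(=O)c1ccc(CNc2nc3cc(N)cc(N)c3nc2-c2ccccc2)cc1` gives 501 nM in this assay. Compound 3 `Nc1cc(N)c2nc(-c3ccccc3)c(NCc3ccc(Cl)c(Cl)c3)nc2c1` gives 1620 nM in this assay. Among these three numbers compound 3 stands second highest: its nearest neighbour is compound 2, whose number is lower by a gap beyond the usual scatter, and its furthest is compound 1, whose number is higher by a gap also beyond the scatter. Compound 1 and compound 3 both carry a 3,4-dichlorophenyl, yet the way it is joined to the core differs, and so do their numbers.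

Compound 4 `COc1ccc(CNc2nc3cc(N)cc(N)c3nc2-c2ccccc2)cc1OC` has not yet been measured. It differs from compound 3 in one place: 3,4-dimethoxyphenyl in place of 3,4-dichlorophenyl on a saturated chain carbon bound to a nitrogen on an aromatic ring. Within the data shown here, no measured pair shows this exact exchange, so any expectation rests on the three measured compounds alone. Compound 2, with a quite different group at that same place, gives 501 nM in this assay, a lower number than compound 3, which suggests that this place accepts other groups without loss. The expected step is a 1.1-fold lower number from compound 3 to compound 4 (0.03 log units; within the scatter), essentially none beyond the scatter. Compound 4 is therefore estimated at 1500 nM in this assay, with a range from 400 nM to 6000 nM.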

Compound 4, concentration for 50% growth inhibition: 3310 nM
For compound 4 the middle estimate is 2.2-fold (0.34 log units) below the measured one, and the stated range covers the measured number.
By their numbers in this assay, from the lowest: compound 2; then compound 3; then compound 4; then compound 1.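

Among these compounds, compound 3 and compound 4 give the first direct reading at this place with the ring held constant: in this assay, 3,4-dimethoxyphenyl in place of 3,4-dichlorophenyl gives a 2.0-fold higher number from compound 3 to compound 4 (0.31 log units; beyond the scatter). The step is modest, but it shows that growth inhibition on this read-out responds to the groups carried on this ring, and that the exchange of chlorine for methoxy groups gives weaker inhibition here, not an unchanged result. The exchange brings in more heavy atoms and adds hydrogen-bond acceptors where there were none, but nothing measured here separates these differences or explains the step.

Both chlorine atoms leave and both methoxy groups enter in the same exchange, so this single step cannot show whether one of them matters more, or how a compound with just one chlorine or one methoxy group on the ring would behave. Also open, as far as these compounds go, is how a plain phenyl, or a phenyl carrying an amine or a carboxylic acid, would compare at this place, and whether a longer chain between the nitrogen and the ring would shift the number.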